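Isopentyl to butyl on the 3,5-dimethoxyphenyl compound

The compounds below may be only part of what the source reports. "The series", "measured", "known", "first", "only" and "open" are said of these compounds alone.

So far, three compounds with a shared core have been measured in a functional assay on HCC827 cells (Homo sapiens) for inhibition, read by fluorescence, with a stated time of 72 h; a lower number here means a stronger inhibitor of growth, a higher number a weaker inhibitor of growth. There, compound 1 (`CCCCn1cnc2c(NCc3cccc(Cl)c3)nc(N[C@H]3CC[C@H](N)CC3)nc21`) gives 10600 nM. Compound 2 (`CC(C)CCn1cnc2c(NCc3cccc(Cl)c3)nc(N[C@H]3CC[C@H](N)CC3)nc21`) gives 16700 nM. Compound 3 (`COc1cc(Nc2nc(N[C@H]3CC[C@H](N)CC3)nc3c2ncn3CCC(C)C)cc(OC)c1`) gives 11200 nM. The number for compound 3 is not set apart from the other two, since it lies within the scatter of both compound 1 and compound 2.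

Compound 4 (`CCCCn1cnc2c(Nc3cc(OC)cc(OC)c3)nc(N[C@H]3CC[C@H](N)CC3)nc21`) has not yet been measured. It differs from compound 3 by hydrogen in place of methyl on a saturated chain carbon bound to two saturated chain carbons, so that isopentyl becomes butyl.

Going by the values given here, the closest precedent is the opposite change, a 1.6-fold higher number from compound 1 to compound 2 (0.20 log units; within the scatter), with methyl in place of hydrogen at that place. Reversed, it points weakly toward a lower number, although it lies within the scatter. The other measured step, a 1.5-fold lower number from compound 2 to compound 3 (0.17 log units; within the scatter), has 3,5-dimethoxyphenyl in place of 3-chlorobenzyl and also lies within the scatter. Neither gives grounds for a large change, so no shift beyond the scatter is expected. The expected change is a 1.2-fold lower number from compound 3 to compound 4 (0.09 log units; within the scatter). For compound 4 the estimated value is 9000 nM, with an expected range from 4500 nM to 18000 nM.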

Compound 4, concentration for 50% growth inhibition: 20100 nM
Compound 4: middle estimate off by 2.2-fold (0.35 log units), on the low side, outside the stated range (above it).
By their numbers in this assay, from the lowest: compounds 1, 3, 2 and 4 (each within the scatter of the next).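

In this assay, the change from isopentyl to butyl on the 3,5-dimethoxyphenyl compound gives a 1.8-fold higher number from compound 3 to compound 4 (0.25 log units; within the scatter), a step that is within the scatter on its own but does not follow the earlier chain step once the two are set side by side, so the effect of a methyl at this place on a saturated chain carbon depends on the rest of the molecule: the same change on two cores in this assay, a 1.6-fold higher number (0.20 log units; within the scatter) from compound 1 to compound 2 and a 1.8-fold lower number (0.25 log units; within the scatter) from compound 4 to compound 3, 2.8-fold (0.45 log units) apart, beyond the scatter of two such steps. The fourth compound also lets the exchange of 3-chlorobenzyl for 3,5-dimethoxyphenyl be read on the butyl series, where it gives a 1.9-fold higher number from compound 1 to compound 4 (0.28 log units; within the scatter), and this exchange likewise does not carry over unchanged from the isopentyl series: the same change on two cores in this assay, a 1.5-fold lower number (0.17 log units; within the scatter) from compound 2 to compound 3 and a 1.9-fold higher number (0.28 log units; within the scatter) from compound 1 to compound 4, 2.8-fold (0.45 log units) apart, beyond the scatter of two such steps. Among these four compounds, then, the chain and the group on the aromatic ring nitrogen cannot be read as independent contributions, although no single step leaves the scatter.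

Whether this dependence holds elsewhere stays open, as only two chains and two nitrogen substituents are shown, all with numbers in a narrow band. A longer chain such as hexyl, or a chain ending in an amine or a carboxylic acid, might show whether this place can move the number beyond the scatter at all.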